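Methyl on the amide nitrogen of compound 3

This account rests on a few compounds, and the source may have more. Where it says the series, first, only, none or still open, it means among the compounds named here.

In a physicochemical assay for solubility, at pH 7.4 (on this read-out lower numbers stand for lower solubility and higher numbers for higher solubility), compound 1 (`O=C(N[C@H]1CN(S(=O)(=O)c2ccccc2)C[C@@H]1C(=O)N[C@H]1CCCNC1)c1cc(-c2ccccc2)on1`) gives 94000 nM, compound 2 (`O=C(N[C@H]1CN(S(=O)(=O)c2ccccc2)C[C@@H]1C(=O)N[C@H]1CCCNC1)c1nnc(-c2ccc(F)cc2)s1`) gives 234000 nM and compound 3 (`O=C(N[C@H]1CN(S(=O)(=O)c2ccccc2)C[C@@H]1C(=O)N[C@H]1CCCNC1)c1cc(-c2ccccc2Cl)on1`) gives 12000 nM, the lowest of the three numbers. Compound 4 (`CN(C(=O)c1cc(-c2ccccc2Cl)on1)[C@H]1CN(S(=O)(=O)c2ccccc2)C[C@@H]1C(=O)N[C@H]1CCCNC1`) differs from compound 3 by methyl in place of hydrogen on an amide-type nitrogen. Among the compounds with values here, no measured step touches that nitrogen. The steps of a 2.5-fold higher number from compound 1 to compound 2 (0.40 log units; beyond the scatter) and a 20-fold lower number from compound 2 to compound 3 (1.29 log units; beyond the scatter) exchange a whole group on a carbonyl carbon, and a 7.8-fold lower number from compound 1 to compound 3 (0.89 log units; beyond the scatter) puts chloro in place of hydrogen on an aromatic carbon. They show the spread of the series but give no direction here. In this assay, no step beyond the scatter is expected, and the estimated change is a 1.3-fold higher number from compound 3 to compound 4 (0.12 log units; within the scatter). Compound 4 is expected at 16000 nM, with an estimated range of 5000 nM to 50000 nM.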

Compound 4, solubility: 655000 nM
For compound 4 the middle estimate is 41-fold (1.61 log units) below the measured one; the measured number lies above the stated range.
By their numbers in this assay, from the lowest: compound 3; then compound 1; then compound 2; then compound 4.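

The amide hydrogen of compound 3 is no silent position in this assay: a single carbon entering on this amide-type nitrogen gives a 55-fold higher number from compound 3 to compound 4 (1.74 log units; beyond the scatter) and so moves the read-out well beyond the scatter. The earlier steps shown here changed only the group on the carbonyl carbon or the aromatic carbon and said nothing about this nitrogen. Nothing measured in the series accounts for the step.

The compounds shown leave open whether ethyl or a longer chain on this nitrogen would act as methyl does. As far as these compounds go, whether methyl here gives a similar step with the groups of compound 1 or compound 2 also stays open.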